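A few compounds are considered here, and "the series" means these few. Any claim that something is new, unique, unknown or untested is made for them only; others in the source may bear on it.

Compound 1 `C=C1[C@@H](OC(C)=O)C[C@@H]2[C@](C)(COC=O)[C@H](OC(C)=O)CC[C@@]2(C)[C@@H]1C[C@@H](Nc1ccc(Br)cc1)C1=CCOC1=O` is examined in a functional assay on KB cells (Homo sapiens) for cytotoxicity, read by sulforhodamine B assay; on this read-out lower numbers stand for stronger inhibition and higher numbers for weaker inhibition. In this assay compound 1 gives 24000 nM, the highest of the three numbers recorded so far. Compound 2 `C=C1[C@@H](OC(C)=O)C[C@@H]2[C@](C)(CO[Si](C)(C)C(C)(C)C)[C@H](OC(C)=O)CC[C@@]2(C)[C@@H]1C[C@@H](Nc1cccc2ccccc12)C1=CCOC1=O`, which carries a naphthalen-1-yl group on the amine nitrogen, gives 8930 nM in this assay, and compound 3 `C=C1[C@@H](OC(C)=O)C[C@@H]2[C@](C)(CO[Si](C)(C)C(C)(C)C)[C@H](OC(C)=O)CC[C@@]2(C)[C@@H]1C[C@@H](Nc1ccc(F)cc1)C1=CCOC1=O`, with a 4-fluorophenyl group in that place, gives 5090 nM. The only single-point step among these is a 1.8-fold lower number from compound 2 to compound 3 (0.24 log units; within the scatter).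

Compound 4 `C=C1[C@@H](OC(C)=O)C[C@@H]2[C@](C)(COC=O)[C@H](OC(C)=O)CC[C@@]2(C)[C@@H]1C[C@@H](Nc1cccc(F)c1)C1=CCOC1=O` has not yet been measured in this assay. It differs from compound 1 in one place: 3-fluorophenyl in place of 4-bromophenyl on an amine nitrogen. Among the compounds with values here, no measured step exchanges 4-bromophenyl for 3-fluorophenyl, so the only guidance comes from the step from compound 2 to compound 3, where swapping one aryl group for a fluorophenyl group on the amine nitrogen moved the number only within the scatter, and from compound 3 standing lowest among the three with a fluorophenyl group. The step from compound 1 to compound 4 is therefore expected to be small, at most a modest move towards a lower number, and is estimated as a 1.6-fold lower number from compound 1 to compound 4 (0.20 log units; within the scatter). Compound 4 is expected to give about 15000 nM in this assay, with a plausible range from 6000 nM to 40000 nM.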

Compound 4, half-maximal inhibitory concentration: 28600 nM
For compound 4 the middle estimate is 1.9-fold (0.28 log units) below the measured one; the measured number falls inside the stated range.
By their numbers in this assay, from the lowest: compounds 3 and 2 (each within the scatter of the next); then compounds 1 and 4 (each within the scatter of the next).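

In this assay, the exchange on the amine nitrogen gives a 1.2-fold higher number from compound 1 to compound 4 (0.08 log units; within the scatter), so 4-bromophenyl and 3-fluorophenyl cannot be told apart at this position, although the halogen and its ring position differ between the two group names. Within the data shown here, this is the first aryl exchange read on the core of compound 1, and it stays within the scatter, as does a 1.8-fold lower number from compound 2 to compound 3 (0.24 log units; within the scatter) on the core of compound 2; in this small set, neither aryl exchange at this position separates the compounds it links. No measurement of any property of these groups is at hand to account for the result.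

The compounds shown leave open whether a different group on that nitrogen, such as unsubstituted phenyl, a pyridine ring, 4-methoxyphenyl or a simple alkyl chain, would move the number beyond the scatter. They also leave open how 3-bromophenyl or 4-fluorophenyl would read on the core of compound 1, which would separate the identity of the halogen from its ring position.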